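Cytotoxicity limits and a swapped fluorine

The source may hold more compounds than are shown below. What is called first, only, known or untested is meant among the compounds shown, and "the series" means these compounds.

Values measured in an ADME assay on MT2 cells (Homo sapiens) for cytotoxicity, read by XTT assay, with a stated time of 4 days (a lower number here means that less compound is tolerated, a higher number that more compound is tolerated), are as follows.
Compound 1 `Cc1nc(C(NC(=O)C(=O)Nc2ccc(Cl)c(F)c2)C2CCCCN2)sc1CCO` gives > 41000 nM as a limit
Compound 2 `Cc1nc(C(NC(=O)C(=O)Nc2ccc(F)c(F)c2)C2CCCCN2)sc1CO` gives > 87000 nM as a limit
Compound 3 `Cc1nc(C(NC(=O)C(=O)Nc2ccc(F)cc2F)C2CCCCN2)sc1CCO` gives > 105000 nM as a limit

Compound 3 has no exact number, and its entry of > 105000 nM is only a limit. The other two entries are also limits, so none of the three compounds has a measured half-maximal cytotoxic concentration.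

Compound 4 `Cc1nc(C(NC(=O)C(=O)Nc2ccc(F)c(F)c2)C2CCCCN2)sc1CCO` has not yet been measured. Its difference from compound 3 is 3,4-difluorophenyl in place of 2,4-difluorophenyl on an amide-type nitrogen and in words it places 3,4-difluorophenyl in place of 2,4-difluorophenyl on an amide-type nitrogen. The same atoms are simply joined differently.

Among the measured compounds shown here, the one measured step at this site is a step that the two limits leave unreadable from compound 1 to compound 3 and it therefore gives no size to carry forward. Compound 2 also carries 3,4-difluorophenyl, and its > 87000 nM is likewise a limit.

With no readable step to build on, no change beyond the scatter is expected in this assay and another limit is the likeliest report. The expected step, an at least 1.0-fold lower number from compound 3 to compound 4 (0.02 log units; that floor lies within the scatter) in this estimate, is therefore small. For compound 4 the estimated value is 100000 nM with an expected range from 40000 nM to 200000 nM in this assay.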

Compound 4, half-maximal cytotoxic concentration: > 78200 nM
Compound 4 was reported as a limit (the forecaster's own chance of this, stated with the estimate: 85%); the middle value is on the limit's open side.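

Compound 4 is reported in this assay only as a limit, as are compound 1, compound 2 and compound 3, and none of the steps linking compound 4 to those three compounds can be read. The compounds shown leave open the actual half-maximal cytotoxic concentration of all four, and whether any of these single changes alters it.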